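The source may hold more compounds than are shown below. What is called first, only, known or untested is meant among the compounds shown, and "the series" means these compounds.

Compound 1 `CC(C)(C)c1ccc(-c2nnc(SCCCN3CCN(c4ccccc4)CC3)[nH]2)cc1` gives 97600 nM in a functional assay on THP-1 cells (Homo sapiens) for cytotoxicity, read by MTT assay, with a stated time of 24 h; on this read-out lower numbers stand for stronger inhibition and higher numbers for weaker inhibition.
Compound 3 `Cc1cccc(-c2nnc(SCCCN3CCN(c4ccccc4)CC3)[nH]2)c1` gives 248000 nM in this assay.
Compound 2 `CCN1CCN(CCCSc2nnc(-c3ccc(C)cc3)[nH]2)CC1` gives only a limit of the assay, > 300000 nM, in this assay.

Three compounds share a core built around a thiol-linked chain ending in a piperazine ring, and differ at the ends of that core. Among the two compounds with a number rather than a limit, compound 3 stands at the weaker end: the step of a 2.5-fold higher number from compound 1 to compound 3 (0.41 log units; beyond the scatter), which exchanges the group on the aromatic carbon, is modest but beyond the usual scatter. Compound 2 sits at the limit of > 300000 nM in this assay, at which 1 of the 3 values shown sits, so its value is a limit and not a number.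

The next step keeps everything of compound 3 except the group on the piperazine nitrogen. Compound 4 `Cc1cccc(-c2nnc(SCCCN3CCN(c4ccccn4)CC3)[nH]2)c1` carries the change (pyridin-2-yl in place of phenyl on an amine nitrogen in a ring). No measured pair among these compounds changes this position between two numbers, so nothing shown here tells how large or in which direction such a step runs in this assay. With compound 3 already close to where the assay stops reporting numbers, the expectation for compound 4 is a step of a 1.1-fold higher number from compound 3 to compound 4 (0.05 log units; within the scatter), that is, no change beyond the scatter. Compound 4 is therefore estimated at 280000 nM, within a range of 120000 nM to 650000 nM.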

Compound 4, half-maximal inhibitory concentration: > 300000 nM
Compound 4 gave a limit, no number (the forecaster's own chance of this, stated with the estimate: 45%); middle value at least 1.0-fold (0.02 log units) from the limit.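

The step at this position is the exchange of phenyl for pyridin-2-yl on the piperazine nitrogen, which keeps the count of heavy atoms and adds one hydrogen-bond acceptor, and in this assay it reads as an at least 1.2-fold higher number from compound 3 to compound 4 (0.08 log units; that floor lies within the scatter). That step is only a floor, so the pair does not separate a change too small to matter from a real loss of cytotoxicity of any size; what it does show is that pyridin-2-yl at this place brings no gain that can be seen as a lower number. Compound 4 gives a limit of the assay and not a number, and it joins compound 2 there: the limit of > 300000 nM in this assay, at which 2 of the 4 values shown sit.

Still open, going by these compounds, is the true size of this step, which would need a pair in which both compounds give numbers, such as pyridin-2-yl placed on the compound 1 scaffold. Compound 1 gives 97600 nM, which leaves more room to read a change. Also open, on these data alone, is how this place on the piperazine responds to other groups, such as a pyrimidin-2-yl ring, an acetyl group or a benzyl group.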